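Lengthening a carboxylic acid chain on two different cores

A few compounds are considered here, and "the series" means these few. Any claim that something is new, unique, unknown or untested is made for them only; others in the source may bear on it.

The compounds here share a spiro-fused saturated core carrying an acid chain, and all were tested in a functional assay with Homo sapiens as the target; on this read-out higher numbers stand for weaker inhibition and lower numbers for stronger inhibition. Compound 1, with the structure `O=C(O)CNC1CCC2(CC1)CCN(c1ccncc1)CC2`, is the starting point of the first pair; in this assay compound 1 gives 890 nM. Compound 2, with the structure `O=C(O)CCNC1CCC2(CC1)CCN(c1ccncc1)CC2`, differs from it by carboxymethyl in place of carboxy on a saturated chain carbon bound to an amine nitrogen, and in this assay compound 2 gives 4500 nM. That single change produced a 5.1-fold higher number from compound 1 to compound 2 (0.70 log units; beyond the scatter), so adding one more carbon to the acid chain weakened inhibition.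

Compound 3, with the structure `O=C(O)CCC(=O)N1CCC2(CCC(C(=O)N3CCC(C4CCNCC4)CC3)CC2)CC1`, is built on a different core; the difference between the two cores is not broken down here. In this assay compound 3 gives 50000 nM, the highest number among the three measured compounds. Compound 4, with the structure `O=C(O)CCCC(=O)N1CCC2(CCC(C(=O)N3CCC(C4CCNCC4)CC3)CC2)CC1`, has not yet been measured and differs from compound 3 by carboxymethyl in place of carboxy on a saturated chain carbon, two bonds along the chain from a carbonyl carbon. This is the same kind of change as between compound 1 and compound 2, but the place is not the same: there the acid sat on a saturated chain carbon bound to an amine nitrogen, here it sits on a saturated chain carbon two bonds along the chain from a carbonyl carbon.

Since the earlier lengthening weakened inhibition, and compound 3 already gives 50000 nM, compound 4 is expected to show a 1.4-fold higher number from compound 3 to compound 4 (0.15 log units; within the scatter). Compound 4 is therefore estimated at 70000 nM, with a range from 25000 nM to 200000 nM, and a real chance that only a limit is reported.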

Compound 4, half-maximal inhibitory concentration: 50000 nM
Estimate against measurement, compound 4: 1.4-fold (0.15 log units) above, within the range that was stated.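

In this assay, the extra carbon in the acid chain gave no change at the digits printed from compound 3 to compound 4 (within the scatter), so going from (2-carboxyethyl)carbonyl to (3-carboxypropyl)carbonyl did not move the read-out beyond ordinary repeat variation. Set beside the earlier step, the same lengthening did not carry over at the same size from one core to the other: the same change on two cores in this assay, a 5.1-fold higher number (0.70 log units; beyond the scatter) from compound 1 to compound 2 and no change at the digits printed (within the scatter) from compound 3 to compound 4, 5.1-fold (0.70 log units) apart, beyond the scatter of two such steps. This does not show what sets the two steps apart: the cores differ, and so does the place of the change, which is on a saturated chain carbon bound to an amine nitrogen in one pair and on a saturated chain carbon two bonds along the chain from a carbonyl carbon in the other, and a single pair on each core cannot separate these two differences or support a rule for the wider series.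

The compounds shown leave open what a longer chain would do on either core, and whether the acid chain joined through an amine nitrogen, as in compound 1, would respond to lengthening on the core of compound 3 as it does on its own core. They also leave open whether the carboxylic acid itself is needed, which a primary amide in its place on each core could test.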